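Sulfonyl aryl exchange in a weakly active series

The compounds below may be only part of what the source reports. "The series", "measured", "known", "first", "only" and "open" are said of these compounds alone.

Compound 1 `COc1ccc(-c2cc(=O)c3c(OC)cc(OC)cc3[nH]2)cc1` bears hydrogen on the aromatic nitrogen of the shared core. In a functional assay on KOPN-8 cells (Homo sapiens) for antiproliferative activity, with a stated time of 72 h (a lower number here means that less compound is needed, a higher number that more compound is needed for the effect), compound 1 gives > 31100 nM, which is a limit of this assay (the limit of > 31100 nM in this assay, at which 1 of the 3 values shown sits). Compound 2 `COc1ccc(-c2cc(=O)c3c(OC)cc(OC)cc3n2C)cc1` gives 30000 nM in this assay, and an at least 1.0-fold lower number from compound 1 to compound 2 (0.01 log units; that floor lies within the scatter) stays within the scatter. Compound 3 `COc1ccc(-c2cc(=O)c3c(OC)cc(OC)cc3n2S(=O)(=O)c2ccc(C=O)cc2)cc1` gives > 34400 nM in this assay, again a limit (the limit of > 34400 nM in this assay, at which 1 of the 3 values shown sits). Hence compound 3 stands at a limit, with an at least 1.1-fold higher number from compound 2 to compound 3 (0.05 log units; that floor lies within the scatter) and a step that the two limits leave unreadable from compound 1 to compound 3. Compound 4 `COc1ccc(-c2cc(=O)c3c(OC)cc(OC)cc3n2S(=O)(=O)c2cccc([N+](=O)[O-])c2)cc1` differs by 3-nitrophenyl in place of 4-formylphenyl on a sulfonyl sulfur. Among the measured compounds shown here, no measured step touches the aryl on the sulfonyl sulfur, and all three measured values sit near or at a limit, so the expected step is a step that the limit leaves unreadable from compound 3 to compound 4, none beyond the scatter. Compound 4 is estimated at 35000 nM, between 15000 nM and 100000 nM, most likely returned as a limit.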

Compound 4, half-maximal effective concentration: > 39600 nM
Compound 4: only a limit was reported; the forecaster's own chance of this, stated with the estimate: 75%; at least 1.1-fold (0.05 log units) between middle value and limit.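

Compound 4 gives > 39600 nM, a limit, and compound 3 also stands at a limit; the step between them cannot be read. The compounds shown leave open whether any aryl on the sulfonyl sulfur gives a value short of a limit in this assay.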